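The compounds below may be only part of what the source reports. "The series", "measured", "known", "first", "only" and "open" are said of these compounds alone.

Measured so far in a functional assay on MDA-MB-231 cells (Homo sapiens) for cytotoxicity, read by MTT assay, with a stated time of 24 h; on this read-out higher numbers stand for weaker inhibition and lower numbers for stronger inhibition:
- compound 1 `CCCCCCCCCCCCCC(=O)Nc1nnc(S[C@@H]2O[C@H](COC(C)=O)[C@H](OC(C)=O)[C@H](OC(C)=O)[C@H]2OC(C)=O)s1`: 26200 nM
- compound 2 `CCCCCCCCCC(=O)Nc1nnc(S[C@@H]2O[C@H](COC(C)=O)[C@H](OC(C)=O)[C@H](OC(C)=O)[C@H]2OC(C)=O)s1`: 19200 nM
- compound 3 `CCCCCCCCCCCCCCCCCC(=O)Nc1nnc(S[C@@H]2O[C@H](CO)[C@H](O)[C@H](O)[C@H]2O)s1`: 67100 nM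

Compound 3 stands highest of the three numbers; its gaps to compound 1 and to compound 2 both lie beyond the scatter, so compound 3 is the weakest of the measured set. Among the compounds with values here, the only step between compounds differing in one place is a 1.4-fold lower number from compound 1 to compound 2 (0.14 log units; within the scatter), a chain-length change that stays within the scatter.

Compound 4 `CCCCCCCC/C=C\CCCCCCCC(=O)Nc1nnc(S[C@@H]2O[C@H](CO)[C@H](O)[C@H](O)[C@H]2O)s1` differs from compound 3 by dec-1-en-1-yl in place of decyl on a saturated chain carbon, seven bonds along the chain from a carbonyl carbon. Within the data shown here, no measured step introduces a double bond into the chain, so nothing here bears directly on the change; the one chain step, a 1.4-fold lower number from compound 1 to compound 2 (0.14 log units; within the scatter), gives no reason to expect a step beyond the scatter. Compound 4 is therefore expected near compound 3, with a 1.0-fold lower number from compound 3 to compound 4 (0.01 log units; within the scatter), estimated at 65000 nM (range 30000 nM to 140000 nM).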

Compound 4, half-maximal inhibitory concentration: 43600 nM
Compound 4: middle estimate off by 1.5-fold (0.17 log units), on the high side; measured number inside the range.
By their numbers in this assay, from the lowest: compounds 2, 1, 4 and 3 (each within the scatter of the next, the first and the last beyond it).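

In this assay, dec-1-en-1-yl in place of decyl, seven bonds along the chain from a carbonyl carbon, gives a 1.5-fold lower number from compound 3 to compound 4 (0.19 log units; within the scatter). Within the data shown here, this is the first reading of a double bond at this position, and with the saturated and unsaturated chains of equal heavy-atom count, the change cannot be told from the scatter. Nothing available explains the result. Still open, going by these compounds, is whether an amine, a carboxylic acid or a longer chain in place of dec-1-en-1-yl would give a step beyond the scatter, and whether the same double bond reads alike in the acetylated compounds.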